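The source may report more compounds than this note shows. Statements on the series, on what has been measured and on what is new or still open speak of the compounds shown alone.

Measured in a functional assay on HeLa cells (Homo sapiens) for antiproliferative activity, read by MTT assay, with a stated time of 48 h; on this read-out higher numbers stand for weaker inhibition and lower numbers for stronger inhibition:
- compound 1 `Cn1cc(-c2cnc3ccnc(N)c3c2)cn1`: 40800 nM
- compound 2 `Cn1cc(-c2cnc3ccc(NCC4CC4)nc3c2)cn1`: > 50000 nM (a limit)
- compound 3 `COc1ccc(CNc2ccc3ncc(-c4cnn(C)c4)cc3n2)cc1`: > 50000 nM (a limit)

Within the data shown here, compound 1 holds the only actual number in this small set. Compounds 2 and 3 give no number, and what they show is the limit of > 50000 nM in this assay, at which 2 of the 3 values shown sit.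

The unmeasured compound 4 `CCNc1nccc2ncc(-c3cnn(C)c3)cc12` keeps the core of compound 1 and turns its amino group into ethylamino: ethyl in place of hydrogen on a nitrogen on an aromatic ring. Among the measured compounds shown here, no measured step covers this change. For the measured compounds named here, the one step available is a step that the two limits leave unreadable from compound 2 to compound 3, so it offers no size to carry over. Compounds 2 and 3 are built on a differently arranged core, but each carries a group on a nitrogen on an aromatic ring. Compound 3 is the closer reminder here, since its > 50000 nM is a limit.

A step beyond the usual scatter is therefore not expected in this assay, and a limit in place of a number is quite possible. The expected step is a 1.2-fold higher number from compound 1 to compound 4 (0.09 log units; within the scatter). For compound 4 the estimated value is 50000 nM, with an expected range of 22000 nM to 100000 nM.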

Compound 4, half-maximal inhibitory concentration: > 50000 nM
Compound 4: only a limit was reported; the forecaster's own chance of this, stated with the estimate: 60%; the middle value sits exactly at the limit.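

In this assay, ethyl in place of hydrogen on the nitrogen on the aromatic ring gives an at least 1.2-fold higher number from compound 1 to compound 4 (0.08 log units; that floor lies within the scatter). Compound 4 gives > 50000 nM, which is a limit and not a number, so only a floor for this step is known. Unlike the step between compounds 2 and 3, which cannot be read, this change is on the core of compound 1 and starts from a real number, yet it still ends at the same limit as those compounds: the limit of > 50000 nM in this assay, at which 3 of the 4 values shown sit.

On these data alone, it remains open whether methyl or a longer chain such as propyl on this nitrogen would give a number in this assay rather than a limit. Among these compounds, it is also open whether an acetyl group there would give a number clearly lower than the one for compound 1, 40800 nM.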